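Moving One Fluorine Within a Difluorophenyl Group

This account rests on a few compounds, and the source may have more. Where it says the series, first, only, none or still open, it means among the compounds named here.

Of the compounds shown here, three have been measured in a functional assay on CHO cells with adenosine receptor A1 (Homo sapiens) as the target, read by cAMP accumulation and immunoassay, with a stated time of 6 min, tested at 10 uM; on this read-out lower numbers stand for a stronger effect and higher numbers for a weaker effect at the one concentration tested. Compound 1 `Nc1scc(CN2CCN(c3ccc(Cl)cc3F)CC2)c1C(=O)c1ccc(Cl)cc1` gives -81%, compound 2 `COc1ccc(N2CCN(Cc3csc(N)c3C(=O)c3ccc(Cl)cc3)CC2)cc1` gives -52%, and compound 3 `Nc1scc(CN2CCN(c3ccc(F)cc3F)CC2)c1C(=O)c1ccc(Cl)cc1` gives -82%. On these numbers compound 3 stands lowest of the three; its nearest neighbour is compound 1, separated by a number 1 percentage points lower from compound 1 to compound 3 (within the scatter), while compound 2 lies furthest, separated by a number 30 percentage points lower from compound 2 to compound 3 (beyond the scatter).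

Compound 4 `Nc1scc(CN2CCN(c3ccc(F)c(F)c3)CC2)c1C(=O)c1ccc(Cl)cc1` differs from compound 3 in one place: 3,4-difluorophenyl in place of 2,4-difluorophenyl on an amine nitrogen in a ring. For the measured compounds named here, no measured step moves a fluorine within the same ring, so the nearest guidance comes from the steps on this group. The step with fluoro in place of chloro, a number 1 percentage points lower from compound 1 to compound 3 (within the scatter), was within the scatter, whereas the two steps involving 4-methoxyphenyl, a number 29 percentage points higher from compound 1 to compound 2 (beyond the scatter) and a number 30 percentage points lower from compound 2 to compound 3 (beyond the scatter), were beyond it. Because a number 1 percentage points lower from compound 1 to compound 3 (within the scatter) was within the scatter, compound 4 is expected to show a number 6 percentage points higher from compound 3 to compound 4 (within the scatter), a step not beyond the scatter. Compound 4 is therefore estimated at -76%, within a range from -92% to -52%.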

Compound 4, a percentage reported as activity, at one concentration (the size of the read-out at that concentration, not a potency): -87%
Compound 4: the middle estimate sits 11 percentage points above what was measured; low and high end bracket the measured number.
By their numbers in this assay, from the lowest: compounds 4, 3 and 1 (each within the scatter of the next); then compound 2.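

In this assay, moving one fluorine within the group on the ring nitrogen gives a number 5 percentage points lower from compound 3 to compound 4 (within the scatter), so the 2,4-difluorophenyl and 3,4-difluorophenyl groups cannot be told apart at this position. The step to the group without a fluorine at the 2-position of the phenyl ring, a number 6 percentage points lower from compound 1 to compound 4 (within the scatter), also stays within the scatter, which shows that a fluorine there, shared by compound 1 and compound 3, is not required for an effect of this size. The 4-methoxyphenyl group remains the one that stands apart, with a number 35 percentage points lower from compound 2 to compound 4 (beyond the scatter).

Nothing shown here explains why these halogenated phenyl groups read alike. The compounds also leave open how an unsubstituted phenyl, a phenyl bearing a single fluorine, or a pyridine ring in this place would read out.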